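This account rests on a few compounds, and the source may have more. Where it says the series, first, only, none or still open, it means among the compounds named here.

Measured in a functional assay (Cavia porcellus) with Rattus norvegicus as the target (on this read-out lower numbers stand for an effect already at smaller amounts and higher numbers for an effect only at larger amounts of compound), so far:

Compound 1, `CCCOC1(c2ccc(Cl)cc2)SC=C(C)n2c1noc2=O`: 890 nM
Compound 2, `CCCOC1(c2ccc(Br)cc2)SC=C(C)n2c1noc2=O`: 410 nM
Compound 3, `CCCCCCCC/C=C\CCCCCCCCO[C@@]1(c2ccc(Cl)cc2)SC=C(C)n2c1noc2=O`: 870 nM

Compounds 1 and 2 share a core and differ in one place: bromo in place of chloro on an aromatic carbon. This change gave a 2.2-fold lower number from compound 1 to compound 2 (0.34 log units; beyond the scatter). Compound 3 carries a different core, and the difference between the two cores is not broken down here. What the values show is that compound 3 and compound 1 lie within the scatter of each other in this assay, while compound 3 sits above compound 2 by a gap beyond the scatter.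

Compound 4, `CCCCCCCC/C=C\CCCCCCCCO[C@@]1(c2ccc(Br)cc2)SC=C(C)n2c1noc2=O`, is not yet measured. It stands to compound 3 as compound 2 stands to compound 1: bromo in place of chloro on an aromatic carbon. The place of the change is described in the same words in both pairs, so it is the same change on a different core.

Within the data shown here, only one measured example of this change exists, so the expectation rests on that single pair. Because a 2.2-fold lower number from compound 1 to compound 2 (0.34 log units; beyond the scatter) was seen on the core of compound 1, the same step is expected on the core of compound 3, giving an estimated 2.2-fold lower number from compound 3 to compound 4 (0.34 log units; beyond the scatter). Compound 4 is therefore expected to come out near 400 nM, with a range from 200 nM to 800 nM to allow for the scatter and for the core difference that is not broken down.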

Compound 4, half-maximal effective concentration: 1260 nM
Compound 4: middle estimate off by 3.2-fold (0.50 log units), on the low side; the whole stated range lies below it.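

In this assay, going from 4-chlorophenyl to 4-bromophenyl on the core of compound 3 gave a 1.4-fold higher number from compound 3 to compound 4 (0.16 log units; within the scatter), so this pair stays within the usual spread of repeated measurements and shows no clear effect of the exchange. Set beside the earlier pair, the same exchange did not carry over unchanged from one core to the other, and the result on one core was not a reliable guide to the result on the other: the same change on two cores in this assay, a 2.2-fold lower number (0.34 log units; beyond the scatter) from compound 1 to compound 2 and a 1.4-fold higher number (0.16 log units; within the scatter) from compound 3 to compound 4, 3.1-fold (0.50 log units) apart, beyond the scatter of two such steps This does not show which part of the difference between the two cores accounts for the gap, and with only two pairs it gives no general rule for this exchange across the series, nor any reason for the disagreement.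

The compounds shown leave open how fluoro, iodo or methyl would read out on the same aromatic carbon, on either core. They also leave open whether a third core, for instance one with a butyl chain or with an amine at the end of its chain, would follow the pair of compound 1 and compound 2, the pair of compound 3 and compound 4, or neither.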